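Swapping the dialkylamino chain: from compound 2 to compound 3

This account rests on a few compounds, and the source may have more. Where it says the series, first, only, none or still open, it means among the compounds named here.

Measured compounds:
compound 1 `CCCCN(CCCC)c1cc(C)nc2c(-c3ccc(Cl)cc3Cl)nn(C)c12` — 0.62 nM
compound 2 `CCCCCN(CCC)c1cc(C)nc2c(-c3ccc(Cl)cc3Cl)nn(C)c12` — 1.2 nM

For the measured compounds named here, in an assay on HEK293 cells for displacement of a labelled ligand from corticotropin-releasing factor receptor 1 (Homo sapiens) (a higher number here means a weaker inhibitor, a lower number a stronger inhibitor), compound 2 gives 1.2 nM, the highest of the two numbers, though its only neighbour, compound 1, differs from it by a 1.9-fold higher number from compound 1 to compound 2 (0.29 log units; within the scatter), a gap within the scatter. Compound 3 `CCN(CCCOC)c1cc(C)nc2c(-c3ccc(Cl)cc3Cl)nn(C)c12` is built from compound 2 by ethyl(3-methoxypropyl)amino in place of pentyl(propyl)amino on an aromatic carbon. Going by the values given here, the single measured step bears on this only loosely: it also exchanges the two chains on the amino nitrogen, and it stayed within the scatter, so the shared core tolerates one such swap. The new change shortens the chains and brings in an oxygen, which nothing measured here addresses. The expectation is therefore a small rise in the number, roughly a 2.1-fold higher number from compound 2 to compound 3 (0.32 log units; beyond the scatter), not clearly beyond the scatter. Compound 3 is estimated at 2.5 nM, with a range from 0.8 nM to 8 nM.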

Compound 3, inhibition constant: 12.5 nM
For compound 3 the middle estimate is 5.0-fold (0.70 log units) below the measured one; the measured number lies above the stated range.
By their numbers in this assay, from the lowest: compounds 1 and 2 (each within the scatter of the next); then compound 3.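

The earlier pair showed only that this aromatic carbon of the shared core can take a different pair of chains without a shift beyond the scatter, and the new result shows that this tolerance has a limit. In this assay, ethyl(3-methoxypropyl)amino gives a 10-fold higher number from compound 2 to compound 3 (1.02 log units; beyond the scatter) against pentyl(propyl)amino, and a 20-fold higher number from compound 1 to compound 3 (1.30 log units; beyond the scatter) against dibutylamino, so the choice of chains at this position can change the number substantially. Nothing available explains the loss or separates the part played by the ethyl chain from that of the 3-methoxypropyl chain.

Ethyl(pentyl)amino, with an all-carbon chain in place of 3-methoxypropyl, would help separate those two parts of the change. Also open, as far as these compounds go, is whether a hydroxyl or an amine at the end of the chain would behave like the methoxy group.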